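Hydroxy to allyloxy: the step from compound 1 to compound 4

The source may hold more compounds than are shown below. What is called first, only, known or untested is meant among the compounds shown, and "the series" means these compounds.

compound 1, `O=C(c1cccnc1)c1ccccc1O`: 24600 nM in a functional assay on MCF7 cells (Homo sapiens) for cytotoxicity, read by sulforhodamine B assay, with a stated time of 48 h; on this read-out lower numbers stand for stronger inhibition and higher numbers for weaker inhibition
compound 2, `O=C(c1cccnc1)c1ccc(Br)cc1O`: > 100000 nM in this assay, a limit
compound 3, `Cc1ccc(O)c(C(=O)c2cccnc2)c1`: 8040 nM in this assay

Compound 1 holds the highest of the two numbers in this assay; compound 3 sits nearest, a 3.1-fold lower number from compound 1 to compound 3 (0.49 log units; beyond the scatter). Compound 2 sits at a limit, (the limit of > 100000 nM in this assay, at which 1 of the 3 values shown sits). Compound 4, `C=CCOc1ccccc1C(=O)c1cccnc1`, differs from compound 1 by allyl in place of hydrogen on an oxygen on an aromatic ring. Neither measured step touches that oxygen: an at least 4.0-fold higher number from compound 1 to compound 2 (0.60 log units; beyond the scatter) and a 3.1-fold lower number from compound 1 to compound 3 (0.49 log units; beyond the scatter) both concern substitution on an aromatic carbon, so they bear on it only by showing that a single change moves the number modestly in either direction. No direction can be expected with confidence. For compound 4 the estimate is 30000 nM in this assay, between 8000 nM and 100000 nM, which means an expected step of a 1.2-fold higher number from compound 1 to compound 4 (0.09 log units; within the scatter).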

Compound 4, half-maximal inhibitory concentration: > 100000 nM
Compound 4 was reported as a limit; the forecaster's own chance of this, stated with the estimate: 25%; middle value at least 3.3-fold (0.52 log units) away from the limit.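

Going by these compounds alone, the first change at the oxygen on an aromatic ring moves the number up in this assay: an at least 4.0-fold higher number from compound 1 to compound 4 (0.60 log units; beyond the scatter). Within the data shown here, earlier steps concerned only aromatic carbons, so this is the first sign that replacing the hydrogen on that oxygen is not neutral here. Compound 4 is reported only as a limit, so the step has a floor but no measured size: the limit of > 100000 nM in this assay, at which 2 of the 4 values shown sit.

From the compounds shown here alone, whether this rise belongs to allyl itself or to any group on that oxygen remains open. A methyl ether, a longer chain or a carboxylic acid there would separate these readings.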